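The source may hold more compounds than are shown below. What is called first, only, known or untested is meant among the compounds shown, and "the series" means these compounds.

Within the data shown here, compound 2 `COc1cc2nc(N3CCN(S(=O)(=O)c4ccc(C(C)(C)C)cc4)CC3)nc(N)c2cc1OC` gives 4100 nM in a functional assay on PC-3 cells (Homo sapiens) for inhibition (on this read-out lower numbers stand for stronger inhibition and higher numbers for weaker inhibition), and stands lowest of the two numbers measured so far; compound 1 `COc1cc2nc(N3CCN(S(=O)(=O)c4ccc(S(C)(=O)=O)cc4)CC3)nc(N)c2cc1OC` gives 17000 nM in this assay. Among the measured compounds shown here, the single measured step is a 4.1-fold lower number from compound 1 to compound 2 (0.62 log units; beyond the scatter), a modest step that is nevertheless beyond the scatter.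

Compound 3 `COc1cc2nc(N3CCN(S(=O)(=O)c4ccc(-c5ccc(C)cc5)cc4)CC3)nc(N)c2cc1OC` is the next member: it differs from compound 2 by 4-methylphenyl in place of tert-butyl on an aromatic carbon. For the measured compounds named here, no measured step covers a swap of this kind, since the only step known exchanges methylsulfonyl for tert-butyl, so the expectation rests on that step alone. Because the step of a 4.1-fold lower number from compound 1 to compound 2 (0.62 log units; beyond the scatter) lowered the number when a group with no donors or acceptors replaced one that carried acceptors, and the 4-methylphenyl group likewise carries none, the expected direction for compound 3 is toward a lower number, though the larger group adds uncertainty and the step may remain within the scatter.

For compound 3 the estimate in this assay is 2500 nM, with a range from 800 nM to 8000 nM, corresponding to an expected step of a 1.6-fold lower number from compound 2 to compound 3 (0.21 log units; within the scatter).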

Compound 3, half-maximal inhibitory concentration: 3400 nM
Estimate against measurement, compound 3: 1.4-fold (0.13 log units) below; low and high end bracket the measured number.
By their numbers in this assay, from the lowest: compounds 3 and 2 (each within the scatter of the next); then compound 1.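

In this assay, the step of a 1.2-fold lower number from compound 2 to compound 3 (0.08 log units; within the scatter) shows that this position, para to a large group, accepts 4-methylphenyl with its 7 carbon atoms and aromatic ring in place of tert-butyl with its 4 carbon atoms and no ring, with the two values remaining within the scatter of each other. The step of a 5.0-fold lower number from compound 1 to compound 3 (0.70 log units; beyond the scatter) now stands with the step of a 4.1-fold lower number from compound 1 to compound 2 (0.62 log units; beyond the scatter), so two different all-carbon groups each give a modest separation from the methylsulfonyl compound that lies beyond the scatter, and neither step goes against this pattern within these three compounds. Nothing measured in the series bears on what underlies these steps.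

The three compounds leave open whether the shared separation from methylsulfonyl extends to other groups at this position, such as an amine, a carboxylic acid or a longer alkyl chain. They also leave open whether a plain phenyl or a 4-methylphenyl carrying a further substituent would stay within the scatter of the tert-butyl and 4-methylphenyl compounds.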